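This account rests on a few compounds, and the source may have more. Where it says the series, first, only, none or still open, it means among the compounds named here.

Measured in a functional assay on MGC-803 cells (Homo sapiens) for cytotoxicity, read by MTT assay, with a stated time of 72 h; a lower number here means a stronger inhibitor, a higher number a weaker inhibitor:
Compound 1 `COc1ccc(Nc2cc(C)nc(SCc3nc4ccccc4[nH]3)n2)cc1`: 51100 nM.
Compound 2 `Cc1cc(NCCO)nc(SCc2nc3ccccc3[nH]2)n1`: > 100000 nM, a limit of the assay rather than a number.
Compound 3 `Cc1cc(NNC(N)=S)nc(SCc2nc3ccccc3[nH]2)n1`: > 100000 nM, likewise a limit.

Compound 2 therefore stands at the limit of > 100000 nM in this assay, at which 2 of the 3 values shown sit, so only a floor is known for it. Compound 4 `Cc1ccc(Nc2cc(C)nc(SCc3nc4ccccc4[nH]3)n2)cc1` differs from compound 2 by 4-methylphenyl in place of 2-hydroxyethyl on a nitrogen on an aromatic ring. Among the compounds with values here, the one measured step that bears on this change runs in the opposite direction: an at least 1.9-fold higher number from compound 1 to compound 2 (0.29 log units; that floor lies within the scatter), where an aryl group on that nitrogen gave way to the 2-hydroxyethyl chain. Restoring an aryl group, here 4-methylphenyl, is expected to reverse that step and to return compound 4 to a number near compound 1. The step expected is an at least 2.0-fold lower number from compound 2 to compound 4 (0.30 log units; that floor lies within the scatter). Compound 4 is estimated at 50000 nM, within a range from 20000 nM to 150000 nM.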

Compound 4, half-maximal inhibitory concentration: 7390 nM
For compound 4 the middle estimate is 6.8-fold (0.83 log units) above the measured one; measured number below the stated range.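

In this assay, 4-methylphenyl on the nitrogen gives an at least 13-fold lower number from compound 2 to compound 4 (1.13 log units; beyond the scatter) and, against the group in compound 3, an at least 13-fold lower number from compound 3 to compound 4 (1.13 log units; beyond the scatter) in a gain now beyond the scatter. Both steps start from a limit, not a number: the limit of > 100000 nM in this assay, at which 2 of the 4 values shown sit. The ring's substituent also counts, since methyl in place of methoxy on an aromatic carbon gives a 6.9-fold lower number from compound 1 to compound 4 (0.84 log units; beyond the scatter) between two true numbers.

From the compounds shown here alone, whether a chloro group or a plain phenyl ring would match methyl remains open. So does whether a longer alkyl chain on that nitrogen would behave like the aryl groups.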